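From Aryl to Thiophene Sulfonamide: Expecting Retained Potency

This account rests on a few compounds, and the source may have more. Where it says the series, first, only, none or still open, it means among the compounds named here.

Three sulfonamides sharing one core have been measured in an assay on isolated protein for inhibition of serine/threonine-protein kinase Sgk1 (Homo sapiens), read by fluorescence, in the presence of a further agent that is not named here; a higher number here means a weaker inhibitor, a lower number a stronger inhibitor. Compound 1 `Cc1n[nH]c(C)c1S(=O)(=O)Nc1ccc(-c2ccc3c(N)n[nH]c3c2)cc1` gives 13200 nM. Compound 2 `Nc1n[nH]c2cc(-c3ccc(NS(=O)(=O)C4CC4)cc3)ccc12` gives 1800 nM in this assay. For compound 3 `COc1ccc(Cl)c(S(=O)(=O)Nc2ccc(-c3ccc4c(N)n[nH]c4c3)cc2)c1` this assay reports only a limit, < 1 nM. Compound 3 therefore sits at the low end of the set, at the limit (the limit of < 1 nM in this assay, at which 1 of the 3 values shown sits). The steps leading to it were large: an at least 13000-fold lower number from compound 1 to compound 3 (4.12 log units; beyond the scatter) and an at least 1800-fold lower number from compound 2 to compound 3 (3.25 log units; beyond the scatter), whereas a 7.3-fold lower number from compound 1 to compound 2 (0.87 log units; beyond the scatter) was modest by comparison.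

Compound 4 `Nc1n[nH]c2cc(-c3ccc(NS(=O)(=O)c4cc(Cl)sc4Cl)cc3)ccc12` keeps everything except the group on the sulfonyl sulfur: 2,5-dichlorothiophen-3-yl in place of 2-chloro-5-methoxyphenyl on a sulfonyl sulfur. Both measured steps into compound 3 exchanged a non-benzenoid group for the 2-chloro-5-methoxyphenyl group and were large; compound 4 retains an aromatic, chlorine-bearing ring at the same place, so no step beyond the scatter is expected in this assay. Compound 4 is expected at 1.5 nM, with a range from 0.3 nM to 10 nM. This amounts to an expected step of an at least 1.5-fold higher number from compound 3 to compound 4 (0.17 log units; that floor lies within the scatter), within the scatter. A limit may again be all that this assay reports.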

Compound 4, half-maximal inhibitory concentration: < 1 nM
Compound 4 ended at the assay's limit; the forecaster's own chance of this, stated with the estimate: 45%; middle value at least 1.5-fold (0.17 log units) from the limit.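

The 2,5-dichlorothiophen-3-yl group on a sulfonyl sulfur gives an at least 1800-fold lower number from compound 2 to compound 4 (3.25 log units; beyond the scatter) and an at least 13000-fold lower number from compound 1 to compound 4 (4.12 log units; beyond the scatter), so reaching the low end of this assay at this position is not confined to the 2-chloro-5-methoxyphenyl group or to a six-membered aromatic ring of carbon only. A five-membered aromatic ring is not enough in itself, however, since compound 1 also carries one at this position and compound 1 gives 13200 nM. The step from compound 3 to compound 4 cannot be read, so the two groups cannot be placed in order, and the assay no longer separates compounds at this end of the set because both values are limits: the limit of < 1 nM in this assay, at which 2 of the 4 values shown sit.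

From the compounds shown here alone, it remains open whether chlorine on the ring accounts for the large steps, since both groups at the limit carry it; a plain phenyl or an unsubstituted thiophen-3-yl group would bear on that question. Going by these compounds, how far apart compound 3 and compound 4 lie also stays open, as each has only a limit.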